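This account rests on a few compounds, and the source may have more. Where it says the series, first, only, none or still open, it means among the compounds named here.

Working notes on the series. Among the compounds with values here, in a functional assay on A549 cells (Homo sapiens) for cytotoxicity, read by MTT assay, with a stated time of 72 h (a higher number here means a weaker inhibitor, a lower number a stronger inhibitor), compound 1 `CN(C)Cc1ccc2nc(NC(=O)N/N=C/c3cn(Cc4ccccc4Cl)c4ccccc34)sc2c1` gives 1080 nM and compound 2 `CN(C)Cc1ccc2nc(NC(=O)N/N=C/c3cn(Cc4ccc(C(C)(C)C)cc4)c4ccccc34)sc2c1` gives 1850 nM, so the two values lie within the scatter of each other and compound 2 stands level with the only other measured compound. The next compound to be measured is compound 3 `CC1CCN(Cc2ccc3nc(NC(=O)N/N=C/c4cn(Cc5ccc(C(C)(C)C)cc5)c5ccccc45)sc3c2)CC1`, which keeps the 4-(tert-butyl)phenyl group of compound 2 and changes the amine: 4-methylpiperidin-1-yl in place of dimethylamino on a saturated chain carbon bound to an aromatic carbon.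

Within the data shown here, only one measured step is available, a 1.7-fold higher number from compound 1 to compound 2 (0.23 log units; within the scatter). It is a change of 4-(tert-butyl)phenyl in place of 2-chlorophenyl on a saturated chain carbon bound to an aromatic nitrogen, so it lies elsewhere in the structure and bears on the new change only indirectly. Among the measured compounds shown here, no measured pair replaces dimethylamino, which leaves neither the size nor the direction of this step defined. With compound 2 at 1850 nM as the starting point, no shift beyond the scatter is assumed, and the range is kept wide on both sides. The expected change is a 1.2-fold lower number from compound 2 to compound 3 (0.09 log units; within the scatter). For compound 3 the estimated value in this assay is 1500 nM, with an expected range of 450 nM to 5000 nM.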

Compound 3, half-maximal inhibitory concentration: 3710 nM
Estimate against measurement, compound 3: 2.5-fold (0.39 log units) below; measured number inside the range.
By their numbers in this assay, from the lowest: compounds 1, 2 and 3 (each within the scatter of the next, the first and the last beyond it).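

In this assay, within the data shown here, the change from (dimethylamino)methyl to (4-methylpiperidin-1-yl)methyl gives a 2.0-fold higher number from compound 2 to compound 3 (0.30 log units; within the scatter), the first reading of a change on this saturated chain carbon bound to an aromatic carbon. With the 4-(tert-butyl)phenyl group held fixed, replacing the 3 heavy atoms of dimethylamino with the 7 of 4-methylpiperidin-1-yl and adding a six-membered non-aromatic ring produces no step beyond the scatter, so this single pair sets no direction for the position. Nothing at hand offers an explanation for the size of this step.

The compounds shown do not separate the ring from its methyl group, a question that a plain piperidin-1-yl or a morpholin-4-yl group at the same place would address. Also open, going by these compounds, is whether the same change of amine would read alike alongside the 2-chlorophenyl group of compound 1, and whether an amine carrying a hydrogen on nitrogen, such as methylamino, would stay within the scatter of compound 2.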